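The compounds below may be only part of what the source reports. "The series", "measured", "known", "first", "only" and "open" are said of these compounds alone.

The shared core appears in compound 1 `O=C(Nc1ccccc1)c1c(NO)cc(-c2ccc(Cl)cc2)oc1=O` and compound 2 `O=C(Nc1ccc(Cl)cc1)c1c(NO)cc(-c2ccccc2)oc1=O`. In an ADME assay on Huh-7 cells (Homo sapiens) for cytotoxicity, read by a luciferase reporter and WST assay, with a stated time of 3 days (a higher number here means that more compound is tolerated, a lower number that less compound is tolerated), compound 1 gives 11000 nM. For compound 2 the result in this assay is only a limit of the assay, > 20000 nM; this reading is the limit of > 20000 nM in this assay, at which 1 of the 2 values shown sits. Compound 3 `COc1ccc(NC(=O)c2c(NO)cc(-c3ccccc3)oc2=O)cc1` has not yet been measured; it differs from compound 2 by methoxy in place of chloro on an aromatic carbon. Within the data shown here, since no measured pair here carries this change, the expected step is a step that the limit leaves unreadable from compound 2 to compound 3, in either direction no larger than the usual scatter. Compound 3 is therefore estimated at 25000 nM, expected to fall between 10000 nM and 60000 nM.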

Compound 3, half-maximal cytotoxic concentration: > 20000 nM
Compound 3: a limit, no number; the forecaster's own chance of this, stated with the estimate: 60%; the middle value is on the limit's open side.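

No step from compound 2 to compound 3 can be read, since both results are limits of the assay and not numbers: the limit of > 20000 nM in this assay, at which 2 of the 3 values shown sit.

On these data alone, whether methoxy in place of chloro changes the tolerated concentration in this assay at all, and in which direction, stays open.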